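A few compounds are considered here, and "the series" means these few. Any claim that something is new, unique, unknown or untested is made for them only; others in the source may bear on it.

Working notes on the series. In an ADME assay on microsomes from liver (Homo sapiens) for pharmacokinetics (a lower number here means slower removal, a higher number faster removal of the compound), compound 2 `Cc1nn(C2COC2)cc1Nc1nc(N)c2c(C#N)c(N3CCC[C@H]3C)n(C)c2n1` gives 46.7 mL/min/kg and compound 1 `Cc1c(Nc2nc(N)c3c(C#N)c(N4CCC[C@H]4C)n(C)c3n2)cnn1C` gives 41.7 mL/min/kg. The measured step between them is a 1.1-fold higher number from compound 1 to compound 2 (0.05 log units; within the scatter), so compound 2 stands level with compound 1 on these numbers. Compound 3 `Cc1nn(C2CCOC2)cc1Nc1nc(N)c2c(C#N)c(N3CCC[C@H]3C)n(C)c2n1` gives 76.7 mL/min/kg; 200 mL/min/kg (2 entries). As the several entries of compound 3 in this assay, 76.7 mL/min/kg; 200 mL/min/kg (2 entries) shows, its entries do not agree on one number, so it sets no step size and only keeps the upper end of any range open.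

The next change leads to compound 4 `Cc1nn(CC(C)(C)O)cc1Nc1nc(N)c2c(C#N)c(N3CCC[C@H]3C)n(C)c2n1`: 2-hydroxy-2-methylpropyl in place of oxetan-3-yl on an aromatic nitrogen. Among the measured compounds shown here, the only measured step that bears on this is a 1.1-fold higher number from compound 1 to compound 2 (0.05 log units; within the scatter), which also brought in the oxetan-3-yl group and stayed within the scatter. No shift beyond the scatter is therefore expected in this assay, and no direction can be claimed. The expected step is a 1.2-fold lower number from compound 2 to compound 4 (0.07 log units; within the scatter). Compound 4 is estimated at 40 mL/min/kg, with an expected range of 18 mL/min/kg to 90 mL/min/kg.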

Compound 4, clearance: 50 mL/min/kg
Compound 4: the middle estimate sits 1.3-fold (0.10 log units) below what was measured, and the stated range covers the measured number.
By their numbers in this assay, from the lowest: compounds 1, 2 and 4 (each within the scatter of the next).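

In this assay, 2-hydroxy-2-methylpropyl in place of oxetan-3-yl on the aromatic nitrogen gives a 1.1-fold higher number from compound 2 to compound 4 (0.03 log units; within the scatter). This adds something the earlier step could not show: oxetan-3-yl carries no hydrogen-bond donor and has a four-membered ring, whereas the entering group has a hydrogen-bond donor and no ring, yet the number shows no shift beyond the scatter at this position. Compound 3, with a different ring on the same nitrogen, gives no clear reading, and its entries leave it without a single number: the several entries of compound 3 in this assay, 76.7 mL/min/kg; 200 mL/min/kg (2 entries)

On these data alone, whether a primary amine or a carboxylic acid on this aromatic nitrogen would move the number beyond the scatter remains open. As far as these compounds go, it is equally open whether a longer chain ending in a hydroxyl group would stay level with compound 4.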